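Acid dissociation across the diamine series: compound 4 from compound 1

The source may hold more compounds than are shown below. What is called first, only, known or untested is meant among the compounds shown, and "the series" means these compounds.

Measured so far:
compound 1 `COc1ccc(F)cc1CNCCCNc1ccnc2cc(CCc3ccccc3)ccc12` — 9.47
compound 2 `COc1cccc(CNCCCNc2ccnc3cc(-c4cc(C(F)(F)F)cc(C(F)(F)F)c4)ccc23)c1O` — 9.47
compound 3 `c1ccc(CCc2ccc3c(NCCCNCc4ccco4)ccnc3c2)cc1` — 9.47

In a physicochemical assay for acid dissociation, compound 1 gives 9.47, level with compounds 2 and 3 at the digits printed. Among the measured compounds shown here, the only step between two compounds that differ in one place, no change at the digits printed from compound 1 to compound 3 (within the scatter), exchanges the group on the saturated chain carbon bound to the amine nitrogen and leaves the read-out unmoved within the scatter. Compound 2 differs from compound 1 both at the fused ring and at the amine end; even so, compound 2 also gives 9.47, so neither end of the molecule has yet shifted the number.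

Compound 4 `COc1ccc(F)cc1CNCCCNc1ccnc2cc(-c3ccc(C(C)(C)C)cc3)ccc12` is not yet measured. It differs from compound 1 in one place: 4-(tert-butyl)phenyl in place of phenethyl on an aromatic carbon. This exchange sits at the fused ring, away from the chain bearing the two amine nitrogens, where the step from compound 1 to compound 3 already showed no movement. For the measured compounds named here, no measured step bears on an exchange at this particular aromatic carbon, but the values of compounds 1, 2 and 3 agree across substituents at that position. The expected step of no change at the digits printed from compound 1 to compound 4 (within the scatter) is therefore none beyond the scatter. For compound 4 the estimate is 9.47, expected to lie between 9.2 and 9.75.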

Compound 4, acid dissociation constant: 9.47
The estimate for compound 4 equals the measured number at the digits printed; low and high end bracket the measured number.
By their numbers in this assay, from the lowest: compounds 1, 2, 3 and 4 (each within the scatter of the next).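

In this assay, among the compounds shown here, the exchange of phenethyl for 4-(tert-butyl)phenyl on the aromatic carbon gives no change at the digits printed from compound 1 to compound 4 (within the scatter), the first single-place step that can be read at this position of the shared core. Together with no change at the digits printed from compound 1 to compound 3 (within the scatter), on the saturated chain carbon bound to an amine nitrogen, this gives one step at each of two separate places in the series, and neither lies beyond the scatter. At the aromatic carbon the step covers a move from 8 to 10 heavy atoms, all carbon, with one six-membered aromatic ring of carbon only, no hydrogen-bond donors or acceptors and no net charge on either side, and nothing in hand accounts for the flat read-out.

Going by these compounds, both groups compared at this aromatic carbon are carbon only, so it remains open whether a group carrying an amine, a carboxylic acid or a nitrile there would leave the number in place. Also open is whether a longer chain bearing the two amine nitrogens would move the read-out, since every compound shown keeps the same chain.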